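Lengthening the amino ester chain on the shared core

The source may hold more compounds than are shown below. What is called first, only, known or untested is meant among the compounds shown, and "the series" means these compounds.

Compound 1, `CCCCc1c(F)c(N)c2c(=O)cc(-c3ccc(N)c(F)c3)oc2c1F`, gives > 100000 nM in a functional assay on HeLa cells (Homo sapiens) for cytotoxicity, read by neutral red uptake, with a stated time of 3 days; a higher number here means a weaker inhibitor, a lower number a stronger inhibitor; this value is a limit of the assay, not a number.
Compound 2, `CCCCCCc1c(F)c(N)c2c(=O)cc(-c3ccc(N)c(F)c3)oc2c1F`, gives 21000 nM in this assay.
Compound 3, `CN(C)CC(=O)OCc1c(F)c(N)c2c(=O)cc(-c3ccc(N)c(F)c3)oc2c1F`, gives 9200 nM in this assay.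

Among the two measured numbers, compound 3 has the lowest, with compound 2 nearest: a 2.3-fold lower number from compound 2 to compound 3 (0.36 log units; beyond the scatter). Compound 4, `CN(C)CCCC(=O)OCc1c(F)c(N)c2c(=O)cc(-c3ccc(N)c(F)c3)oc2c1F`, differs from compound 3 in one place: 2-(dimethylamino)ethyl in place of dimethylamino on a saturated chain carbon bound to a carbonyl carbon. Going by the values given here, the only measured step that lengthens a chain is an at least 4.7-fold lower number from compound 1 to compound 2 (0.67 log units; beyond the scatter), which lowered the number in this assay; the steps of an at least 10-fold lower number from compound 1 to compound 3 (1.03 log units; beyond the scatter) and a 2.3-fold lower number from compound 2 to compound 3 (0.36 log units; beyond the scatter) exchange an alkyl chain for the amino ester and bear less directly on this change. A modest lowering is therefore expected, a 1.8-fold lower number from compound 3 to compound 4 (0.26 log units; within the scatter), though a step within the scatter cannot be excluded. Compound 4 is estimated at 5000 nM, between 1500 nM and 20000 nM.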

Compound 4, half-maximal inhibitory concentration: 4500 nM
The estimate for compound 4 lay 1.1-fold (0.05 log units) above the measured number; measured number inside the range.
By their numbers in this assay, from the lowest: compound 4; then compound 3; then compound 2. At a limit, above all of these: compound 1.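

Lengthening the chain, with 2-(dimethylamino)ethyl in place of dimethylamino on a saturated chain carbon bound to a carbonyl carbon, gives a 2.0-fold lower number from compound 3 to compound 4 (0.31 log units; beyond the scatter) in this assay, so this position of the amino ester responds to chain length. Compared with the hexyl chain of compound 2, the longer amino ester gives a 4.7-fold lower number from compound 2 to compound 4 (0.67 log units; beyond the scatter) and the gap to the butyl compound reads an at least 22-fold lower number from compound 1 to compound 4 (1.34 log units; beyond the scatter) in the same assay. That last step starts from a limit of the assay, not a number: the limit of > 100000 nM in this assay, at which 1 of the 4 values shown sits.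

As far as these compounds go, whether a still longer chain before the dimethylamino group lowers the number further remains open. So does the effect of replacing dimethylamino with a primary amine or with piperidine.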